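Hydroxymethyl added on the amide chain carbon: compound 4

The source may hold more compounds than are shown below. What is called first, only, known or untested is meant among the compounds shown, and "the series" means these compounds.

Measured so far in an assay on CHO cells for displacement of a labelled ligand from adenosine receptor A1 (Homo sapiens), read by scintillation counting, with a stated time of 60 min, tested at 10 uM; on this read-out higher numbers stand for more inhibition at the one concentration tested (going by the name of the read-out) and lower numbers for less inhibition:
- compound 1 `COc1cccc2cc(C(=O)NCC(=O)O)c(=O)oc12`: 27%
- compound 2 `COc1cccc2cc(C(=O)Nc3c(C#N)ncn3-c3ccc(C#N)cc3)c(=N)oc12`: 18%
- compound 3 `COCCNC(=O)c1cc2cccc(OC)c2oc1=N`: reported only as a limit, > 70%

Compound 1 and compound 2 give numbers that lie within the usual scatter of each other, so no order between the two can be read from them. Compound 3 stands at a limit of this assay rather than at a number (the limit of > 70% in this assay, at which 1 of the 3 values shown sits); it is the only one of the three to do so. Going by the values given here, no pair of measured compounds differs in a single place, so no measured step is available to lean on.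

Compound 4 `COc1cccc2cc(C(=O)N[C@@H](CO)C(=O)O)c(=O)oc12` keeps the core of compound 1 and its amide-linked acid chain; the change is hydroxymethyl in place of hydrogen on a saturated chain carbon bound to an amide-type nitrogen and a carbonyl carbon. The chain carbon that carries the new group sits between the amide nitrogen and the carbonyl carbon of the acid, and the acid itself is kept. With no measured step of this kind in the series, the step from compound 1 to compound 4 is expected to be small, not clearly beyond the scatter in either direction, a number 2 percentage points lower from compound 1 to compound 4 (within the scatter). Compound 4 is therefore estimated to give 25% in this assay, within 5% to 48%.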

Compound 4, a percentage reported as inhibition, at one concentration (the size of the read-out at that concentration, not a potency): 12%
Estimate against measurement, compound 4: 13 percentage points above, within the range that was stated.
By their numbers in this assay, from the lowest: compounds 4, 2 and 1 (each within the scatter of the next, the first and the last beyond it). At a limit, above all of these: compound 3.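

Going by these compounds alone, the saturated chain carbon bound to an amide-type nitrogen and a carbonyl carbon responds to substitution: in this assay hydroxymethyl in place of hydrogen gives a number 15 percentage points lower from compound 1 to compound 4 (beyond the scatter) as the only single-place step, and a modest one. The acid is kept in this step, so the lower inhibition comes with a change on the chain carbon alone and not with any change to the acid. The data at hand give no cause for this step.

As far as these compounds go, it remains open whether the step follows the hydroxyl or the added carbon, and methyl on the same chain carbon would separate the two. Also open, from the compounds shown here alone, is how that carbon behaves with an amine or a longer chain in place of hydroxymethyl, and whether the step holds with an ester in place of the carboxylic acid.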